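This account rests on a few compounds, and the source may have more. Where it says the series, first, only, none or still open, it means among the compounds named here.

Measured so far in a functional assay on DLA cells (Mus musculus) for cytotoxicity, read by MTT assay, with a stated time of 48 h; a lower number here means a stronger inhibitor, a higher number a weaker inhibitor:
Compound 1 `COc1ccc(C(=O)c2cc(C)ccc2OCC(=O)NNC(=O)c2cc3ccccc3oc2=O)cc1` gives 42000 nM.
Compound 2 `Cc1ccc(OCC(=O)NNC(=O)c2cc3ccccc3oc2=O)c(C(=O)c2ccccc2Br)c1` gives 10000 nM.
Compound 3 `Cc1ccc(OCC(=O)NNC(=O)c2cc3ccccc3oc2=O)c(C(=O)c2ccc(Cl)cc2)c1` gives 59100 nM.

Compound 3 has the highest number of the three; its gap to compound 1, a 1.4-fold higher number from compound 1 to compound 3 (0.15 log units; within the scatter), lies within the scatter, while the step of a 5.9-fold higher number from compound 2 to compound 3 (0.77 log units; beyond the scatter) lies beyond it. Compound 4 `Cc1ccc(OCC(=O)NNC(=O)c2cc3ccccc3oc2=O)c(C(=O)c2cccc(Br)c2)c1` differs from compound 3 in one place: 3-bromophenyl in place of 4-chlorophenyl on a carbonyl carbon. For the measured compounds named here, the step of a 5.9-fold higher number from compound 2 to compound 3 (0.77 log units; beyond the scatter) is the one that bears on this change, but it concerned the 2-bromophenyl group, not the 3-bromophenyl group now entering, so the new group has no direct precedent; the step of a 4.2-fold lower number from compound 1 to compound 2 (0.62 log units; beyond the scatter) likewise concerned the 2-bromophenyl group only. Going by the values given here, a modest downward step is therefore expected, a 2.4-fold lower number from compound 3 to compound 4 (0.37 log units; beyond the scatter), smaller than the one seen for compound 2. Compound 4 is estimated at 25000 nM, with a range of 8000 nM to 65000 nM.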

Compound 4, half-maximal inhibitory concentration: 68500 nM
For compound 4 the middle estimate is 2.7-fold (0.44 log units) below the measured one; the whole stated range lies below it.
By their numbers in this assay, from the lowest: compound 2; then compounds 1, 3 and 4 (each within the scatter of the next).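

In this assay, the bromine alone does not account for the low number of compound 2: 3-bromophenyl in place of 2-bromophenyl on the carbonyl carbon gives a 6.9-fold higher number from compound 2 to compound 4 (0.84 log units; beyond the scatter). The 3-bromophenyl group instead falls in with the other two groups, with a 1.2-fold higher number from compound 3 to compound 4 (0.06 log units; within the scatter) and a 1.6-fold higher number from compound 1 to compound 4 (0.21 log units; within the scatter), both within the scatter, so only the 2-bromophenyl compound stands apart. Nothing measured here explains this difference. From the compounds shown here alone, whether 2-chlorophenyl or 2-methoxyphenyl on this carbonyl carbon would give a similarly low number remains open.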